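Pyrrolidin-1-yl for dimethylamino: clearance notes on compound 2

The source may report more compounds than this note shows. Statements on the series, on what has been measured and on what is new or still open speak of the compounds shown alone.

Within the data shown here, the series so far holds three compounds that all carry the dimethylamino group: compound 1 `CN(C)c1ccc2cc(-c3cccc(Cl)c3Cl)c(N)nc2c1` and compound 2 `CN(C)c1ccc2cc(-c3cc(Cl)cc(Cl)c3)c(N)nc2c1` and compound 3 `CN(C)c1ccc2cc(-c3nc4ccccc4s3)c(N)nc2c1` differ from one another in a single other group. In an ADME assay on microsomes from liver (Mus musculus) for metabolic stability, read by HPLC, with a stated time of 4 h (a higher number here means faster removal of the compound, a lower number slower removal), compound 1 gives 360 mL/min/kg while compound 2 gives 210 mL/min/kg and compound 3 gives 280 mL/min/kg under the same conditions. Compound 2 stands within the scatter of both other compounds, so these three numbers cannot be put in any order.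

The next compound is compound 4 `Nc1nc2cc(N3CCCC3)ccc2cc1-c1cc(Cl)cc(Cl)c1` with pyrrolidin-1-yl in place of dimethylamino on an aromatic carbon, and the rest of compound 2 is left unchanged (pyrrolidin-1-yl in place of dimethylamino on an aromatic carbon). Among the measured compounds shown here, no measured pair isolates this change, so the data give no direct size for it. For the measured compounds named here, the only guide is that replacing the other group leaves compound 1 at 360 mL/min/kg and compound 3 at 280 mL/min/kg within the scatter of compound 2 at 210 mL/min/kg in this assay so far. No step beyond the scatter is expected, and no direction is favoured. The estimated step is a 1.1-fold higher number from compound 2 to compound 4 (0.06 log units; within the scatter) and it is expected to stay within the scatter. Compound 4 is expected at 240 mL/min/kg with an estimated range of 130 mL/min/kg to 420 mL/min/kg in this assay.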

Compound 4, clearance: 320 mL/min/kg
Estimate against measurement, compound 4: 1.3-fold (0.12 log units) below; the measured number falls inside the stated range.
By their numbers in this assay, from the lowest: compounds 2, 3, 4 and 1 (each within the scatter of the next).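

Among these compounds, compound 2 and compound 4 form the first pair that isolates a change at this position, an aromatic carbon of the six-membered aromatic ring of carbon only: in this assay, pyrrolidin-1-yl in place of dimethylamino gives a 1.5-fold higher number from compound 2 to compound 4 (0.18 log units; within the scatter). Among the compounds shown here, the swap brings in a five-membered non-aromatic ring and raises the group from 3 heavy atoms to 5 while the hydrogen-bond donor and acceptor counts stay the same, and on this single pair that enlargement produces no step that can be told from the scatter. No measurement on hand bears on the reason for this result.

Open, going by these compounds, is whether the same exchange stays within the scatter when the other group of compound 1 or compound 3 is present, since this one pair carries only the group of compound 2. Also open, on these data alone, is how this position responds to a ring with a second hetero atom, such as morpholin-4-yl, to a larger ring such as piperidin-1-yl, or to a group with no amine nitrogen on the aromatic carbon, such as methoxy.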